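The compounds below may be only part of what the source reports. "The series", "measured", "known", "first", "only" and "open" are said of these compounds alone.

Compound 1 `O=S(=O)(Nc1ccc(-c2nc3ccccc3o2)cc1)c1cccs1`: in an assay on isolated protein for inhibition of malate dehydrogenase, mitochondrial (Sus scrofa), with stated times of 45 min and 30 min (a higher number here means a weaker inhibitor, a lower number a stronger inhibitor), compound 1 gives > 63000 nM, a limit of the assay rather than a number.
Compound 2 `O=S(=O)(Nc1ccc(-c2nc3ccccc3o2)cc1)c1cccc(C(F)(F)F)c1`: in this assay compound 2 gives > 63000 nM, again a limit of the assay.

Compound 2 thus stands at the limit of this assay, as does the other measured compound, and both values rest at the limit of > 63000 nM in this assay, at which 2 of the 2 values shown sit. Going by the values given here, no measured pair tells how any change at this position shifts inhibition. Compound 3 `COc1cccc(S(=O)(=O)Nc2ccc(-c3nc4ccccc4o3)cc2)c1` differs from compound 2 by methoxy in place of trifluoromethyl on an aromatic carbon. With both measured values at the limit, no step beyond the scatter is expected in this assay, and the estimated step that the limit leaves unreadable from compound 2 to compound 3 is taken as small. Compound 3 is expected near 100000 nM, within 30000 nM to 400000 nM, most likely reported once more only as a limit.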

Compound 3, half-maximal inhibitory concentration: > 63000 nM
Compound 3 was reported as a limit; the forecaster's own chance of this, stated with the estimate: 85%; the middle value lies beyond the limit too.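

No step among compound 1, compound 2 and compound 3 can be read, since all three values are limits of this assay: the limit of > 63000 nM in this assay, at which 3 of the 3 values shown sit.

The compounds shown leave open whether any group on the sulfonyl sulfur gives a value that is a number in this assay.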